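Benzoxazinone sulfonamides: amide-nitrogen substituent change, compound 3 to 4

The source may hold more compounds than are shown below. What is called first, only, known or untested is meant among the compounds shown, and "the series" means these compounds.

Measured so far:
compound 1 `COc1ccc(N2C(=O)COc3ccc(-c4cnc(OC)c(NS(=O)(=O)c5ccc(F)cc5)c4)cc32)cc1` — 13400 nM
compound 2 `O=C1COc2ccc(-c3cnc(Cl)c(NS(=O)(=O)c4ccc(F)cc4)c3)cc2N1c1ccc(F)cc1` — 34200 nM
compound 3 `COc1ncc(-c2ccc3c(c2)N(c2ccc(F)cc2)C(=O)CO3)cc1NS(=O)(=O)c1ccc(F)cc1` — > 40000 nM

In a functional assay on HCT-116 cells (Homo sapiens) for antiproliferative activity, read by MTT assay, with a stated time of 72 h (a higher number here means a weaker inhibitor, a lower number a stronger inhibitor), compound 1 gives 13400 nM. Compound 2 gives 34200 nM. For compound 3 only a limit of the assay is known, > 40000 nM (the limit of > 40000 nM in this assay, at which 1 of the 3 values shown sits). Compound 3 therefore stands at the weak end of the numbers shown, its distance from compound 1 given by an at least 2.9-fold higher number from compound 1 to compound 3 (0.47 log units; beyond the scatter) and from compound 2 by an at least 1.1-fold higher number from compound 2 to compound 3 (0.06 log units; that floor lies within the scatter).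

Compound 4 `COc1ncc(-c2ccc3c(c2)N(C2CCCCC2)C(=O)CO3)cc1NS(=O)(=O)c1ccc(F)cc1` differs from compound 3 in one place: cyclohexyl in place of 4-fluorophenyl on an amide-type nitrogen in a ring. Among the measured compounds shown here, neither measured step touches this position; both concern the aryl substituent on the pyridine, so no step bears directly on the change. With compound 3 at the limit, no basis exists for expecting a step beyond the scatter in either direction, and compound 4 is estimated at 40000 nM (range 10000 nM to 120000 nM), the expected step being a number no higher from compound 3 to compound 4 (the limit leaves the size open).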

Compound 4, half-maximal inhibitory concentration: > 40000 nM
Compound 4: only a limit was reported (the forecaster's own chance of this, stated with the estimate: 55%); the middle value sits exactly at the limit.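

Compound 3 and compound 4 both end at a limit of this assay, so the step between them cannot be read: the limit of > 40000 nM in this assay, at which 2 of the 4 values shown sit.

Against 4-methoxyphenyl, cyclohexyl on the amide-type nitrogen in a ring gives an at least 2.9-fold higher number from compound 1 to compound 4 (0.47 log units; beyond the scatter). Among compound 1, compound 3 and compound 4, which differ only in this group, only 4-methoxyphenyl gives a number rather than a limit.

As far as these compounds go, how far compound 3 and compound 4 lie beyond the limit stays open. Also open, from the compounds shown here alone, is whether a methyl group, or a longer chain carrying an amine, on this nitrogen would give a number rather than a limit.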